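Trading fluoro and methoxy for two methyls

This account rests on a few compounds, and the source may have more. Where it says the series, first, only, none or still open, it means among the compounds named here.

In a physicochemical assay for solubility, in phosphate buffer, measured as kinetic solubility, at pH 7.4 (on this read-out higher numbers stand for higher solubility and lower numbers for lower solubility), compound 3 `COc1cccc(F)c1-c1nc(CN2CCC(C(=O)NCCCN3C[C@H](C)C[C@H](C)C3)CC2)c(C)o1` stands at > 74 ug/mL, which is a limit and not a number. Compound 1 `COc1cccc(Cl)c1-c1nc(CN2CCC(C(=O)NCCCN3C[C@H](C)C[C@H](C)C3)CC2)c(C)o1` gives > 76 ug/mL, also a limit. Compound 4 `Cc1ccc(-c2nc(CN3CCC(C(=O)NCCCN4C[C@H](C)C[C@H](C)C4)CC3)c(C)o2)cc1C` carries 3,4-dimethylphenyl in place of 2-fluoro-6-methoxyphenyl on an aromatic carbon. The closest measured comparison is compound 2 `CCc1ccccc1-c1nc(CN2CCC(C(=O)NCCCN3C[C@H](C)C[C@H](C)C3)CC2)c(C)o1`, whose 2-ethylphenyl group also holds only carbon and which gives 55.9 ug/mL. The two steps that bear on this, an at least 1.3-fold lower number from compound 1 to compound 2 (0.13 log units; that floor lies within the scatter) and an at least 1.3-fold higher number from compound 2 to compound 3 (0.12 log units; that floor lies within the scatter), have floors within the scatter, so they offer only a weak hint. The step expected is an at least 1.6-fold lower number from compound 3 to compound 4 (0.21 log units; that floor lies within the scatter), probably towards a lower number. Compound 4 is expected at 45 ug/mL, with an estimated range from 15 ug/mL to 80 ug/mL.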

Compound 4, solubility: > 71 ug/mL
Compound 4: a limit, no number; the forecaster's own chance of this, stated with the estimate: 15%; middle value at least 1.5-fold (0.19 log units) away from the limit.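

In this assay compound 4 gives a limit and not a number, so a group of carbon only at this position can also end at a limit, as the groups of compound 1 and compound 3 do. Placing 3,4-dimethylphenyl where 2-ethylphenyl stood gives an at least 1.2-fold higher number from compound 2 to compound 4 (0.10 log units; that floor lies within the scatter), so no real gap between these two carbon-only groups can be claimed. The steps to compound 4 from compound 1 and from compound 3 cannot be read, as both ends of each are limits. From the compounds shown here alone, how the true values of these three compounds compare stays open, as does what an amine or a carboxylic acid on this phenyl ring would give.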